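Compound 3: a new group on the ring nitrogen

A few compounds are considered here, and "the series" means these few. Any claim that something is new, unique, unknown or untested is made for them only; others in the source may bear on it.

Compound 1 `COC(=O)CC/C(C)=C/Cc1c(OC)c(C)c2c(c1OCC#CCN1CCN(c3ccccc3OC)CC1)C(=O)OC2` and compound 2 `COC(=O)CC/C(C)=C/Cc1c(OC)c(C)c2c(c1OCC#CCN1CCN(C(=O)C3COc4ccccc4O3)CC1)C(=O)OC2` share one core and differ only in the group on an amine nitrogen in a ring. In a functional assay on HT-29 cells (Homo sapiens) for inhibition, read by sulforhodamine B assay (on this read-out higher numbers stand for weaker inhibition and lower numbers for stronger inhibition), compound 1 gives > 50000 nM as a limit and not a number. Compound 2 gives > 50000 nM as a limit too. Compound 2 therefore has no number of its own (the limit of > 50000 nM in this assay, at which 2 of the 2 values shown sit). Among the compounds with values here, the one measured step (a step that the two limits leave unreadable from compound 1 to compound 2) offers no size to build on.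

Compound 3 `COC(=O)CC/C(C)=C/Cc1c(OC)c(C)c2c(c1OCC#CCN1CCN(c3ccc(C)cc3)CC1)C(=O)OC2` keeps the core and changes the group on that same nitrogen (4-methylphenyl in place of (2,3-dihydro-1,4-benzodioxin-2-yl)carbonyl on an amine nitrogen in a ring), with 4-methylphenyl in place of (2,3-dihydro-1,4-benzodioxin-2-yl)carbonyl. The closest comparison is compound 1 with its 2-methoxyphenyl on that nitrogen, which gives > 50000 nM as a limit. On that basis, weak inhibition is expected to persist in this assay, with no step beyond the scatter (a number no higher from compound 2 to compound 3 (the limit leaves the size open)). For compound 3 the estimate is 50000 nM with an expected range from 20000 nM to 100000 nM and a good chance that the outcome will be only a limit.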

Compound 3, half-maximal inhibitory concentration: > 50000 nM
Compound 3 ended at the assay's limit; the forecaster's own chance of this, stated with the estimate: 80%; the middle value sits exactly at the limit.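

In this assay, within the data shown here, compound 3 also gives only a limit and not a number, so no step among compound 1, compound 2 and compound 3 can be read: the limit of > 50000 nM in this assay, at which 3 of the 3 values shown sit. The compounds shown leave open how strongly each of them inhibits, and whether any group on that ring nitrogen would give a measurable value.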